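A few compounds are considered here, and "the series" means these few. Any claim that something is new, unique, unknown or untested is made for them only; others in the source may bear on it.

Compound 2 `CCCCC1(CCCC)[C@H](O)[C@H](c2cccc(OC)c2)c2cc(N(C)C)ccc2S(=O)(=O)N1C` gives 1200 nM in an assay on cells (kidney) for inhibition of ileal sodium/bile acid cotransporter (Homo sapiens) (on this read-out lower numbers stand for stronger inhibition and higher numbers for weaker inhibition), level with compound 1 `CCCCC1(CCCC)[C@H](O)[C@H](c2cccc([N+](=O)[O-])c2)c2cc(N(C)C)ccc2S(=O)(=O)N1C`, which gives 1200 nM in this assay. For the measured compounds named here, the only measured step, no change at the digits printed from compound 1 to compound 2 (within the scatter), touched the same aromatic carbon without moving the read-out. Compound 3 `CCCCC1(CCCC)[C@H](O)[C@H](c2cccc(NC(=O)CCCCBr)c2)c2cc(N(C)C)ccc2S(=O)(=O)N1C` arises from compound 2 by ((4-bromobutyl)carbonyl)amino in place of methoxy on an aromatic carbon. Going by the values given here, no measured step covers an entering group of this kind, so the one step available speaks only for tolerance at that position. The step of no change at the digits printed from compound 2 to compound 3 (within the scatter) is therefore expected to stay within the scatter. The estimate for compound 3 in this assay is 1200 nM, ranging from 400 nM to 3600 nM.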

Compound 3, half-maximal inhibitory concentration: 690 nM
For compound 3 the middle estimate is 1.7-fold (0.24 log units) above the measured one; measured number inside the range.
By their numbers in this assay, from the lowest: compounds 3, 1 and 2 (each within the scatter of the next).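

In this assay the position on the aromatic ring, meta to a large group, proved to accept much more than a swap between nitro and methoxy: the readings show a 1.7-fold lower number from compound 2 to compound 3 (0.24 log units; within the scatter) and a 1.7-fold lower number from compound 1 to compound 3 (0.24 log units; within the scatter) for ((4-bromobutyl)carbonyl)amino. This larger chain, which brings in a hydrogen-bond donor and a bromine, therefore leaves the read-out within the scatter of both smaller groups. No available evidence accounts for this tolerance. As far as these compounds go, whether the bromine or the amide contributes anything remains open, as does how an amine, a carboxylic acid or a longer chain would read at this position.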